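A few compounds are considered here, and "the series" means these few. Any claim that something is new, unique, unknown or untested is made for them only; others in the source may bear on it.

Compound 1 `COc1cccc(NC(=O)Nc2ccc(Oc3ncnc4[nH]ncc34)cc2)c1`: > 10000 nM
Compound 2 `O=C(Nc1ccc(Oc2ncnc3[nH]ncc23)cc1)NC1CCCCC1`: > 10000 nM
Compound 3 `O=C(NCC1CCCCC1)Nc1ccc(Oc2ncnc3[nH]ncc23)cc1`: > 10000 nM

Each of these three entries is a limit, not a number. In a functional assay on HeLa cells (Homo sapiens) for inhibition, read by MTT assay, with a stated time of 72 h (a higher number here means a weaker inhibitor, a lower number a stronger inhibitor), compound 3 gives > 10000 nM, a limit that leaves its true position unknown. The series as a whole offers only (the limit of > 10000 nM in this assay, at which 3 of the 3 values shown sit).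

Compound 4 `CC(C)c1cccc(NC(=O)Nc2ccc(Oc3ncnc4[nH]ncc34)cc2)c1` differs from compound 3 in one place, on an amide-type nitrogen, where 3-isopropylphenyl stands in place of cyclohexylmethyl: 3-isopropylphenyl in place of cyclohexylmethyl on an amide-type nitrogen.

The measured steps that bear on this change are a step that the two limits leave unreadable from compound 1 to compound 3 and a step that the two limits leave unreadable from compound 2 to compound 3, and neither has a size that can be read. The nearest neighbour of compound 4 is compound 1, with 3-methoxyphenyl on that nitrogen, and compound 1 gives > 10000 nM, again a limit. Nothing measured therefore points to a step beyond the scatter in either direction in this assay, and compound 4 is expected to stay near that limit.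

The expected change is a step that the limit leaves unreadable from compound 3 to compound 4. For compound 4 the estimated value is 12000 nM, with an expected range from 4000 nM to 30000 nM.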

Compound 4, half-maximal inhibitory concentration: > 10000 nM
Compound 4 was reported as a limit; the forecaster's own chance of this, stated with the estimate: 75%; the middle value does not contradict the limit.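

In this assay compound 4 gives > 10000 nM, again a limit and not a number. The steps linking compound 4 to compound 1, compound 2 and compound 3 therefore cannot be read. The series offers only this: the limit of > 10000 nM in this assay, at which 4 of the 4 values shown sit.

The compounds shown leave open whether any group on the amide-type nitrogen would give a value that can be read as a number.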